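From Arylamine to Piperidine on a Shared Core

The compounds below may be only part of what the source reports. "The series", "measured", "known", "first", "only" and "open" are said of these compounds alone.

Among the compounds with values here, compound 1 `O=C1C=C(Nc2cccc(F)c2)C(=O)c2c1nc1n2[C@H]2OC[C@@H](O)[C@H]2OC1` gives 6440 nM in a functional assay on HeLa cells (Homo sapiens) for inhibition, read by sulforhodamine B assay (on this read-out higher numbers stand for weaker inhibition and lower numbers for stronger inhibition), and this is the only plain number in the set. Compound 2 `O=C1C(N2CCC2)=CC(=O)c2c1nc1n2[C@H]2OC[C@@H](O)[C@H]2OC1`, which carries a small cyclic amine, reaches only > 16000 nM in this assay; that reading is a limit of the assay, not a number (the limit of > 16000 nM in this assay, at which 1 of the 2 values shown sits). Compound 3 `O=C1C=C(N2CCCCC2)C(=O)c2c1nc1n2[C@H]2OC[C@@H](O)[C@H]2OC1` differs from compound 1 by piperidin-1-yl in place of (3-fluorophenyl)amino on a double-bonded ring carbon. Within the data shown here, no step between measured compounds is available, so the expectation rests on the change itself: putting piperidin-1-yl in place of (3-fluorophenyl)amino is expected to weaken inhibition beyond the usual scatter, a 3.1-fold higher number from compound 1 to compound 3 (0.49 log units; beyond the scatter). For compound 3 the estimate is 20000 nM, within 7000 nM to 60000 nM.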

Compound 3, half-maximal inhibitory concentration: > 16000 nM
Compound 3 was reported as a limit; the forecaster's own chance of this, stated with the estimate: 55%; the middle value is on the limit's open side.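

Putting piperidin-1-yl in place of (3-fluorophenyl)amino on this double-bonded ring carbon is a real loss in this assay, with an at least 2.4-fold higher number from compound 1 to compound 3 (0.39 log units; beyond the scatter). Within the data shown here, this is the first measured step at this position, and the change removes both the aromatic ring and the hydrogen-bond donor. The reading for compound 3 is a limit and not a number, so the full size of the step stays unknown: the limit of > 16000 nM in this assay, at which 2 of the 3 values shown sit.

Which of those two losses matters more remains open. Cyclohexylamino, which keeps the donor hydrogen without an aromatic ring, would separate them.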